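The source may report more compounds than this note shows. Statements on the series, on what has been measured and on what is new or still open speak of the compounds shown alone.

Measured in a functional assay on DU-145 cells (Homo sapiens) for cytotoxicity (on this read-out higher numbers stand for weaker inhibition of growth and lower numbers for stronger inhibition of growth), so far:
- compound 1 `COc1ccc(C2=C(c3cc(OC)c(OC)c(OC)c3)CC3CCCN3C2=O)cc1O` gives > 100000 nM (a limit, not a number)
- compound 2 `CSc1ccc(C2=C(c3ccc(C)c(C)c3)C(=O)N3CCCC3C2)cc1` gives 500 nM in the same test
- compound 3 `CSc1ccc(C2=C(c3ccc(F)c(C)c3)C(=O)N3CCCC3C2)cc1` gives 500 nM in the same test

Among the measured compounds shown here, compound 3 stands level with compound 2, and these two are the only compounds here with a real number. Compound 1 sits at a limit of this assay and offers no measured size of effect.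

Compound 4 `CSc1ccc(C2=C(c3ccc(F)cc3)C(=O)N3CCCC3C2)cc1` differs from compound 3 at one place, (hydrogen in place of methyl on an aromatic carbon), which is hydrogen in place of methyl on an aromatic carbon, turning 4-fluoro-3-methylphenyl into 4-fluorophenyl.

For the measured compounds named here, no measured step makes this exact swap. The closest guide is no change at the digits printed from compound 2 to compound 3 (within the scatter), a fluoro-for-methyl swap on the same ring. One small step is thin evidence, so the range is kept wide, and no shift beyond the scatter is expected. The estimated move a 1.2-fold higher number from compound 3 to compound 4 (0.08 log units; within the scatter) is therefore expected to be small, with no firm direction. For compound 4 the expected value is 600 nM, with an estimated range from 200 nM to 2000 nM in this test.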

Compound 4, concentration for 50% growth inhibition: 500 nM
The estimate for compound 4 lay 1.2-fold (0.08 log units) above the measured number, and the stated range covers the measured number.
By their numbers in this assay, from the lowest: compounds 2, 3 and 4 (each within the scatter of the next). At a limit, above all of these: compound 1.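

Taking the methyl group away, so that 4-fluoro-3-methylphenyl becomes 4-fluorophenyl, gives no change at the digits printed from compound 3 to compound 4 (within the scatter) in this assay. The earlier compounds shown here showed only a fluoro group standing in for a methyl group on this ring, whereas this change leaves a plain hydrogen at the methyl position. The wider change, with no change at the digits printed from compound 2 to compound 4 (within the scatter), points the same way, so among compounds 2, 3 and 4 the methyl group on this ring can go without any shift beyond the scatter.

The compounds shown give no reason for this flat result. As far as these compounds go, it remains open whether the same holds for a quite different group at this place on the ring, such as an amine, a carboxylic acid or a longer chain.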